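A Styryl Arm Replaces the Fluorophenyl

This account rests on a few compounds, and the source may have more. Where it says the series, first, only, none or still open, it means among the compounds named here.

Compound 2 `Nc1ncnn2c([C@@H]3O[C@H](CO)[C@@H](O)[C@H]3O)cc(-c3ccccc3F)c12` sits at the edge of what a functional assay on LN-229 cells (Homo sapiens) for antiproliferative activity, with a stated time of 72 h (on this read-out higher numbers stand for weaker inhibition and lower numbers for stronger inhibition), can report. In this assay compound 2 gives > 100000 nM, which is a limit of the assay and not a number. Compound 1 `Nc1ncnn2c([C@@H]3O[C@H](CO)[C@@H](O)[C@H]3O)cc(-c3ccc(Cl)cc3)c12` gives 32600 nM in this assay. Within the data shown here, the one step measured so far, an at least 3.0-fold higher number from compound 1 to compound 2 (0.48 log units; beyond the scatter), runs towards weaker inhibition and lies beyond the scatter, but it carries only a lower bound on its size. Compound 3 `Nc1ncnn2c([C@@H]3O[C@H](CO)[C@@H](O)[C@H]3O)cc(/C=C/c3ccccc3)c12` is yet to be tested; it differs from compound 2 by 2-phenylethenyl in place of 2-fluorophenyl on an aromatic carbon. Among the measured compounds shown here, no measured pair shows this particular exchange, so the step from compound 1 to compound 2 serves only as a reminder that swapping the aromatic arm can move the number noticeably. Because compound 2 rests at the limit of > 100000 nM in this assay, at which 1 of the 2 values shown sits, the direction of the coming step cannot be read from the numbers, and a second limit is a real possibility. Compound 3 is expected to give 70000 nM, within a range from 15000 nM to 300000 nM. The expected change in this assay is an at least 1.4-fold lower number from compound 2 to compound 3 (0.15 log units; that floor lies within the scatter), which is an estimate and not a measurement.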

Compound 3, half-maximal inhibitory concentration: 3900 nM
Beside the measured number, compound 3's estimate is 18-fold (1.25 log units) above it; the whole stated range lies above it.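

Among these compounds, at this aromatic carbon of the shared core, the earlier compounds showed only a loss on changing the aromatic arm, whereas this change brings a clear gain in this assay: 2-phenylethenyl in place of 2-fluorophenyl gives an at least 25-fold lower number from compound 2 to compound 3 (1.40 log units; beyond the scatter). That size is only a floor, because compound 2 sits at a limit of the assay and not at a number: the limit of > 100000 nM in this assay, at which 1 of the 3 values shown sits. The gain also holds against the one arm with a real number, as 2-phenylethenyl in place of 4-chlorophenyl gives an 8.4-fold lower number from compound 1 to compound 3 (0.92 log units; beyond the scatter), so compound 3 has the lowest number of the three, and an arm with a double bond outside its aromatic ring is tolerated here.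

Each of these arms carries one six-membered aromatic ring of carbon only, so the compounds shown leave open whether the gain depends on the double bond itself or would persist with a saturated 2-phenylethyl group at the same carbon. Also open, as far as these compounds go, is whether a chlorine on the phenyl ring of the 2-phenylethenyl arm would lower the number further or raise it again.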